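Para methyl for para nitro on the shared xanthine-type core

The source may report more compounds than this note shows. Statements on the series, on what has been measured and on what is new or still open speak of the compounds shown alone.

Of the compounds shown here, three have been measured in an assay for binding affinity to adenosine receptor A1 (Bos taurus); a lower number here means a stronger inhibitor, a higher number a weaker inhibitor. Compound 1, `C=CCn1c(=O)c2[nH]c(-c3ccc(Cl)cc3N)nc2n(C)c1=O`, gives 2 nM. Compound 2, `Cn1c(=O)c2nc(-c3ccc([N+](=O)[O-])cc3)[nH]c2n(C)c1=O`, gives 8 nM. Compound 3, `CCn1c(=O)c2nc(-c3ccc(S(=O)(=O)NCC(C)O)cc3)[nH]c2n(CC)c1=O`, gives 4.2 nM. Among these three, compound 2 carries the highest number; its gap to compound 3 is within the scatter, so the two cannot be told apart, while its gap to compound 1 is beyond the scatter, compound 1 standing at the lower number.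

Compound 4, `Cc1ccc(-c2nc3c(=O)n(C)c(=O)n(C)c3[nH]2)cc1`, has not yet been measured in this assay. It differs from compound 2 in one place:

methyl in place of nitro on an aromatic carbon

Among the compounds with values here, no pair of measured compounds shows the effect of this change, so the expectation rests only on the values at hand. Because compound 2 gives 8 nM and the group that enters is a single carbon on the same aromatic carbon, compound 4 is expected to stay close to that number. The step of a 1.3-fold higher number from compound 2 to compound 4 (0.10 log units; within the scatter) is expected to be small, not beyond the scatter, with no clear direction. Compound 4 is therefore estimated at 10 nM in this assay, within a range from 3 nM to 40 nM.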

Compound 4, half-maximal inhibitory concentration: 0.8 nM
Estimate against measurement, compound 4: 13-fold (1.10 log units) above; measured number outside the range, below it.
By their numbers in this assay, from the lowest: compound 4; then compound 1; then compounds 3 and 2 (each within the scatter of the next).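

Methyl in place of nitro on the aromatic carbon para to a large group brings a 10-fold lower number from compound 2 to compound 4 (1.00 log units; beyond the scatter) in this assay and so shows that this position is not indifferent to the group it carries. This pair is the first among the compounds shown to differ in one place, and the earlier values could not isolate the contribution of any single group. Here, a nitro with 3 heavy atoms and 2 hydrogen-bond acceptors gives way to a methyl with 1 heavy atom and no hydrogen-bond acceptors, and the number falls, but no evidence is available to explain the direction or size of this step.

The compounds shown leave open whether the lower number comes from losing the nitro or from gaining the methyl, and a bare hydrogen, an ethyl, a methoxy or a carboxylic acid at this position would help separate the two. They also leave open whether the same change would give a similar step on the core of compound 3, which carries ethyl groups where compound 2 carries methyl groups.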